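The source may report more compounds than this note shows. Statements on the series, on what has been measured and on what is new or still open speak of the compounds shown alone.

Three members of this series have been tested in a functional assay on HT-29 cells (Homo sapiens) for inhibition, read by sulforhodamine B assay, with a stated time of 48 h; on this read-out lower numbers stand for stronger inhibition of growth and higher numbers for weaker inhibition of growth. Compound 1 `CC1=CC[C@H](C(C)(C)N=C=S)CC1` is the simplest; in this assay compound 1 gives > 100000 nM, which is a limit of the assay rather than a number (the limit of > 100000 nM in this assay, at which 1 of the 3 values shown sits). Compound 2 `COc1ccc(/C=N/NC(=S)NC(C)(C)[C@H]2CC=C(C)CC2)cc1` gives 33600 nM in this assay. Compound 3 `CC1=CC[C@H](C(C)(C)NC(=S)N/N=C/c2cccc([N+](=O)[O-])c2)CC1` gives 21900 nM in this assay, and the numbers for compound 2 and compound 3 lie within the usual scatter of each other, so they cannot be told apart. Compound 4 `CC1=CC[C@H](C(C)(C)NC(=S)N/N=C/c2ccco2)CC1` differs from compound 2 in one place: furan-2-yl in place of 4-methoxyphenyl on a carbon with a double bond to nitrogen. For the measured compounds named here, no measured pair shows such a change, so no step beyond the scatter is expected. Compound 4 is expected to give about 40000 nM in this assay, between 15000 nM and 100000 nM. That estimate means an expected step of a 1.2-fold higher number from compound 2 to compound 4 (0.08 log units; within the scatter).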

Compound 4, concentration for total growth inhibition: 26900 nM
For compound 4 the middle estimate is 1.5-fold (0.17 log units) above the measured one; low and high end bracket the measured number.
By their numbers in this assay, from the lowest: compounds 3, 4 and 2 (each within the scatter of the next). At a limit, above all of these: compound 1.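

The step of a 1.2-fold lower number from compound 2 to compound 4 (0.10 log units; within the scatter) shows that, in this assay, this position on a carbon with a double bond to nitrogen accepts a five-membered aromatic ring with one hetero atom as well as a six-membered ring of carbon only. Replacing 4-methoxyphenyl with the smaller furan-2-yl therefore leaves the number indistinguishable. Nothing measured here explains this result.

Going by these compounds, it remains open whether a group of a different kind at this position, such as an amine, a carboxylic acid or a longer chain, would move the number beyond the scatter.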